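The source may report more compounds than this note shows. Statements on the series, on what has been measured and on what is new or still open speak of the compounds shown alone.

Measured so far in a functional assay with Neuronal acetylcholine receptor; alpha3/beta4 (Homo sapiens) as the target; on this read-out lower numbers stand for stronger inhibition and higher numbers for weaker inhibition:
compound 1 `CC1(C)CC(=O)N(c2ccccc2C(=O)OCC2CCCN(CCCc3ccccc3)C2)C1=O`: 7500 nM
compound 2 `CCCCC1CC(=O)N(c2ccccc2C(=O)OCC2CCCN(CCCc3ccccc3)C2)C1=O`: 1500 nM
compound 3 `C=CCC1CC(=O)N(c2ccccc2C(=O)OCC2CCCN(CCCc3ccccc3)C2)C1=O`: 1700 nM

Compound 3 gives the second highest number of the three. Its nearest neighbour is compound 2, a step within the scatter: a 1.1-fold higher number from compound 2 to compound 3 (0.05 log units; within the scatter). Its furthest is compound 1, with the gap a 4.4-fold lower number from compound 1 to compound 3 (0.64 log units; beyond the scatter).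

Compound 4 `O=C(OCC1CCCN(CCCc2ccccc2)C1)c1ccccc1C(F)(F)F` is not yet measured. The change is a group of 4 heavy atoms (1 carbon, 3 fluorine; no ring) in place of a group of 10 heavy atoms (7 carbon, 1 nitrogen, 2 oxygen; one five-membered non-aromatic ring with 1 hetero atom), on an aromatic carbon. Every measured step keeps the five-membered ring and only alters the chain on it: a 5.0-fold lower number from compound 1 to compound 2 (0.70 log units; beyond the scatter) and a 4.4-fold lower number from compound 1 to compound 3 (0.64 log units; beyond the scatter) are modest, a 1.1-fold higher number from compound 2 to compound 3 (0.05 log units; within the scatter) is within the scatter. Going by the values given here, no measured step removes the ring group altogether, so these steps bear on the change only weakly. A step in this assay towards a higher number, beyond the scatter, is expected: a 3.5-fold higher number from compound 3 to compound 4 (0.55 log units; beyond the scatter). Compound 4 is estimated at 6000 nM, range 1500 nM to 25000 nM.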

Compound 4, half-maximal inhibitory concentration: 3200 nM
Estimate against measurement, compound 4: 1.9-fold (0.27 log units) above, and the stated range covers the measured number.
By their numbers in this assay, from the lowest: compounds 2, 3 and 4 (each within the scatter of the next, the first and the last beyond it); then compound 1.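

In this assay the ring group on this aromatic carbon gives way to trifluoromethyl, with no ring, and the number stays within the scatter for the allyl-bearing group (a 1.9-fold higher number from compound 3 to compound 4 (0.27 log units; within the scatter)) and only just beyond it for the butyl-bearing group (a 2.1-fold higher number from compound 2 to compound 4 (0.33 log units; beyond the scatter)). Against 3,3-dimethyl-2,5-dioxopyrrolidin-1-yl the same replacement goes the other way (a 2.3-fold lower number from compound 1 to compound 4 (0.37 log units; beyond the scatter)), so the ring group is not needed for numbers of this order. No evidence on why these steps fall as they do is available.

As far as these compounds go, whether an amine or a methoxy group on this aromatic carbon would match trifluoromethyl stays open. So does whether a longer chain on the ring group would lower the number further.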